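The source may report more compounds than this note shows. Statements on the series, on what has been measured and on what is new or still open speak of the compounds shown alone.

Measured in a functional assay on MGC-803 cells (Homo sapiens) for inhibition, read by sulforhodamine B assay; on this read-out higher numbers stand for weaker inhibition and lower numbers for stronger inhibition:

compound 1 `Cc1ccc(NC2=CC(=O)c3nc4n(c3C2=O)[C@H]2OC[C@@H](O)[C@H]2OC4)cc1C`: 860 nM
compound 2 `O=C1C=C(Nc2ccccc2)C(=O)c2c1nc1n2[C@H]2OC[C@@H](O)[C@H]2OC1`: 1730 nM
compound 3 `O=C1C=C(Nc2ccc(I)cc2)C(=O)c2c1nc1n2[C@H]2OC[C@@H](O)[C@H]2OC1`: 1400 nM

All three compounds carry a phenyl group, plain or substituted, on an amine nitrogen of the shared core, and their numbers lie within the scatter of one another. Compound 3 shows no real separation from either of the others, as a 1.2-fold lower number from compound 2 to compound 3 (0.09 log units; within the scatter) and a 1.6-fold higher number from compound 1 to compound 3 (0.21 log units; within the scatter) make plain.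

Compound 4 `O=C1C=C(N2CCCC2)C(=O)c2c1nc1n2[C@H]2OC[C@@H](O)[C@H]2OC1` has not yet been measured. It has pyrrolidin-1-yl in place of (4-iodophenyl)amino on a double-bonded ring carbon.

The measured steps bear on this change only in part. Together with the two above, a 2.0-fold higher number from compound 1 to compound 2 (0.30 log units; within the scatter) completes the set, and all three alter only the substituents on the phenyl group. None of them replaces the whole (4-iodophenyl)amino group, so this change has no direct precedent among these compounds. In this assay the small size of those steps offers no reason to expect a shift beyond the scatter, and they give no firm direction, though the uncertainty is wide.

The expected step, estimated from this limited evidence, is a 1.3-fold higher number from compound 3 to compound 4 (0.11 log units; within the scatter). The estimate for compound 4 is 1800 nM (expected range 500 nM to 6000 nM).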

Compound 4, half-maximal inhibitory concentration: > 16000 nM
Compound 4 ended at the assay's limit (the forecaster's own chance of this, stated with the estimate: 5%); at least 8.8-fold (0.94 log units) between middle value and limit.
By their numbers in this assay, from the lowest: compounds 1, 3 and 2 (each within the scatter of the next). At a limit, above all of these: compound 4.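

The reading for compound 4 is a limit of the assay and not a number: the limit of > 16000 nM in this assay, at which 1 of the 4 values shown sits. In this assay, for the compounds shown here, the change on the double-bonded ring carbon gives an at least 11-fold higher number from compound 3 to compound 4 (1.05 log units; beyond the scatter), an at least 9.2-fold higher number from compound 2 to compound 4 (0.96 log units; beyond the scatter) and an at least 18-fold higher number from compound 1 to compound 4 (1.26 log units; beyond the scatter), the only steps in this set that lie beyond the scatter. The earlier steps shown here changed only the substituents on the phenyl group, whereas these replace the whole arylamino group with pyrrolidin-1-yl, and they show that the position does not accept every amine equally.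

The change swaps a six-membered aromatic ring and 1 hydrogen-bond donor for a five-membered non-aromatic ring and 0 hydrogen-bond donors, so the compounds shown cannot separate the two differences, and the true size of each step remains unknown beyond the limit. On these data alone, it remains open whether a cyclohexylamino group, which pairs a non-aromatic ring with an amine hydrogen, or a methyl(phenyl)amino group, which keeps the phenyl ring without that hydrogen, would read closer to compound 2 or to compound 4.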